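Ring Restored Through an Ethenyl Linker

The source may hold more compounds than are shown below. What is called first, only, known or untested is meant among the compounds shown, and "the series" means these compounds.

Of the compounds shown here, three of one series have been measured in an assay on CHO cells for antagonist activity at transient receptor potential cation channel subfamily V member 1 (Homo sapiens), read by FLIPR and calcium flux; on this read-out lower numbers stand for stronger inhibition and higher numbers for weaker inhibition. Compound 1 `CC(C(=O)NCc1ccc(C(F)(F)F)nc1C1=CCCCC1)c1ccc(NS(C)(=O)=O)c(F)c1` gives 0.7 nM, and compound 2 `CC(C(=O)NCc1ccc(C(F)(F)F)nc1C1=CCC(C)(C)CC1)c1ccc(NS(C)(=O)=O)c(F)c1` gives 0.2 nM, the step between them being a 3.5-fold lower number from compound 1 to compound 2 (0.54 log units; beyond the scatter). Compound 3 `CCC/C=C\c1nc(C(F)(F)F)ccc1CNC(=O)C(C)c1ccc(NS(C)(=O)=O)c(F)c1`, which carries an open-chain pent-1-en-1-yl group where the other two carry a six-membered ring, gives 2.1 nM, the highest number of the three; it stands a 3.0-fold higher number from compound 1 to compound 3 (0.48 log units; beyond the scatter) and an 11-fold higher number from compound 2 to compound 3 (1.02 log units; beyond the scatter).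

Compound 4 `CC(C(=O)NCc1ccc(C(F)(F)F)nc1/C=C/C1CCCCC1)c1ccc(NS(C)(=O)=O)c(F)c1` differs from compound 3 in one place: 2-cyclohexylethenyl in place of pent-1-en-1-yl on an aromatic carbon. The change brings a six-membered carbon ring back, now joined to the aromatic carbon through an ethenyl linker rather than directly as in compounds 1 and 2. Both measured steps that bear on it run the other way, from a ring to the open chain, and both raised the number, modestly from compound 1 and by a large margin from compound 2. Reversing that comparison, a lower number is expected for compound 4, by a 2.6-fold lower number from compound 3 to compound 4 (0.42 log units; beyond the scatter). Compound 4 is estimated at 0.8 nM, within 0.3 nM to 2.5 nM.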

Compound 4, inhibition constant: 0.7 nM
Compound 4: the middle estimate sits 1.1-fold (0.06 log units) above what was measured; the measured number falls inside the stated range.
By their numbers in this assay, from the lowest: compound 2; then compounds 1 and 4 (each within the scatter of the next); then compound 3.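

In this assay the six-membered carbon ring need not sit directly on the aromatic carbon next to the ring nitrogen: the 2-cyclohexylethenyl group gives a 3.0-fold lower number from compound 3 to compound 4 (0.48 log units; beyond the scatter) and, set against the directly attached ring, gives no change at the digits printed from compound 1 to compound 4 (within the scatter). The 4,4-dimethylcyclohex-1-en-1-yl group nevertheless keeps its lead, with a 3.5-fold higher number from compound 2 to compound 4 (0.54 log units; beyond the scatter) as the cost of replacing it. No measurement is at hand that would explain any of these steps.

As far as these compounds go, whether the two methyl groups that lowered the number on the directly attached ring would do the same on the ring of the 2-cyclohexylethenyl group remains open. Also open, from the compounds shown here alone, is how a phenyl ring on the same ethenyl linker, or a saturated 2-cyclohexylethyl group, would compare at this position.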